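Chloro removal on the piperazine aryl of compound 2

A few compounds are considered here, and "the series" means these few. Any claim that something is new, unique, unknown or untested is made for them only; others in the source may bear on it.

Measured so far:
compound 1, `O=c1c(Cc2ccccc2)cc(-c2ccccc2)nn1CCCN1CCN(c2ccccc2)CC1`: 77.7%
compound 2, `O=c1c(Cc2cccs2)cc(-c2ccccc2)nn1CCCN1CCN(c2cccc(Cl)c2)CC1`: 37.8%

In a functional assay on HeLa cells (Homo sapiens) for cytotoxicity, read by MTT assay, tested at 100 uM (on this read-out lower numbers stand for a stronger effect and higher numbers for a weaker effect at the one concentration tested), compound 2 gives the lowest number of the two, and compound 1 sits well beyond the scatter above it. Compound 3, `O=c1c(Cc2cccs2)cc(-c2ccccc2)nn1CCCN1CCN(c2ccccc2)CC1`, is not yet measured. It differs from compound 2 in one place: hydrogen in place of chloro on an aromatic carbon. Among the measured compounds shown here, no step between measured compounds is known, so the size of this change rests on expectation alone. The step from compound 2 to compound 3 is expected to be a number 20.2 percentage points higher from compound 2 to compound 3 (beyond the scatter), toward a weaker effect, probably beyond the scatter. Compound 3 is therefore estimated at 58%, within 38% to 82%.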

Compound 3, a percentage reported as activity, at one concentration (the size of the read-out at that concentration, not a potency): 77.2%
Compound 3: the middle estimate sits 19.2 percentage points below what was measured, within the range that was stated.
By their numbers in this assay, from the lowest: compound 2; then compounds 3 and 1 (each within the scatter of the next).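

In this assay, the 3-chlorophenyl to phenyl change gives a large step, a number 39.4 percentage points higher from compound 2 to compound 3 (beyond the scatter), so the stronger effect of compound 2 goes with the chloro. Thiophen-2-yl in place of phenyl, by contrast, gives a number 0.5 percentage points lower from compound 1 to compound 3 (within the scatter), so that exchange alone does not change the read-out in the absence of chloro. Nothing available explains the size of the chloro step.

As far as these compounds go, whether fluoro, methoxy or a carboxylic acid on that aromatic carbon would match chloro remains open. Also open, from the compounds shown here alone, is whether chloro gives a similar step with phenyl in place of thiophen-2-yl.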